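The source may report more compounds than this note shows. Statements on the series, on what has been measured and on what is new or still open speak of the compounds shown alone.

Measured in a functional assay on MDA-MB-231 cells (Homo sapiens) for inhibition, read by MTT assay, with a stated time of 48 h; a higher number here means a weaker inhibitor, a lower number a stronger inhibitor:

- compound 1 `CCc1ccc(-c2nc3ccccn3c2Sc2ccccc2)cc1`: > 100000 nM (a limit of the assay, not a number)
- compound 2 `Cc1ccc2nc(-c3ccc(Cl)cc3)c(Sc3ccccc3)n2c1`: 94500 nM
- compound 3 `Clc1ccc(Sc2c(-c3ccccc3)nc3ccccn23)cc1`: 57600 nM

Compound 1 gives no number, and its entry is the limit of > 100000 nM in this assay, at which 1 of the 3 values shown sits. Compound 2 gives 94500 nM and compound 3 gives 57600 nM, two values within the usual scatter of each other. All three compounds are therefore weak inhibitors in this assay.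

Compound 4 `c1ccc(Sc2c(-c3ccsc3)nc3ccccn23)cc1` keeps the shared core and the phenylsulfanyl group of compound 1, but carries thiophen-3-yl in place of 4-ethylphenyl on an aromatic carbon. For the measured compounds named here, no two measured compounds differ in one place only, so the data offer no direct guide to the size of this change. The expectation rests on the neighbours alone. With compound 2 at 94500 nM and compound 3 at 57600 nM, compound 4 is expected to fall in the same weak range. That would be a small step towards stronger inhibition, and a result reported only as a limit would be no surprise.

The expected step is an at least 1.4-fold lower number from compound 1 to compound 4 (0.15 log units; that floor lies within the scatter). For compound 4 the estimated value is 70000 nM, with an expected range from 30000 nM to 130000 nM.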

Compound 4, half-maximal inhibitory concentration: 62800 nM
The estimate for compound 4 lay 1.1-fold (0.05 log units) above the measured number; low and high end bracket the measured number.
By their numbers in this assay, from the lowest: compounds 3, 4 and 2 (each within the scatter of the next). At a limit, above all of these: compound 1.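

In this assay, thiophen-3-yl in place of 4-ethylphenyl, on the aromatic carbon of the five-membered ring that lies next to the ring nitrogen, gives an at least 1.5-fold lower number from compound 1 to compound 4 (0.20 log units; that floor lies within the scatter). For the compounds shown here, this is the first look at this position with the rest of the molecule held constant: a five-membered aromatic ring with 5 heavy atoms can replace a six-membered one with 8 and still give a measured number, although the printed floor alone does not establish a real gain in inhibition. The true size of the step cannot be read because compound 1 has no number of its own, only a limit: the limit of > 100000 nM in this assay, at which 1 of the 4 values shown sits.

The compounds shown do not separate the loss of the ethyl group from the change of ring size or the arrival of sulfur, as no pair changes just one of these features. Also open, going by these compounds, is how this carbon would respond to a quite different group, such as an amine or a carboxylic acid on the ring, and whether any group here could lift these compounds out of the weak range.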